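Nitro compound with its double bond drawn as Z

This account rests on a few compounds, and the source may have more. Where it says the series, first, only, none or still open, it means among the compounds named here.

Measured so far (a functional assay on MCF7 cells (Homo sapiens) for cytotoxicity, read by MTT assay, with a stated time of 48 h; on this read-out higher numbers stand for weaker inhibition and lower numbers for stronger inhibition):
- compound 1 `CC(=NNC(=S)Nc1ccccc1F)c1ccccn1` gives 0.39 nM
- compound 2 `C/C(=N/NC(=S)Nc1ccccc1)c1ccccn1` gives 0.18 nM
- compound 3 `CC(=NNC(=S)Nc1ccccc1[N+](=O)[O-])c1ccccn1` gives 5.7 nM

Compound 3 has the highest number of the three, and the values of compound 1 and compound 2 both lie beyond the scatter from it. Compound 4 `C/C(=N/NC(=S)Nc1ccccc1[N+](=O)[O-])c1ccccn1` has the same atoms and bonds as compound 3 (the two compounds have the same atoms and bonds; at least one stereo element is drawn with a configuration in one of them and without one in the other: 1 of 1 stereo elements differ; a double bond is drawn without a configuration in compound 3 and Z in compound 4). Going by the values given here, the only measured step between compounds differing in one place is large (a 15-fold higher number from compound 1 to compound 3 (1.16 log units; beyond the scatter)), but it is nitro in place of fluoro on an aromatic carbon and does not bear directly on a double bond drawn with or without a configuration. Among the compounds with values here, no measured pair isolates that difference, so no step beyond the scatter is expected in this assay and the value of compound 3 remains the best guide. The estimate means a 1.0-fold lower number from compound 3 to compound 4 (0.02 log units; within the scatter) (an expected step, not a measured one). Compound 4 is expected at 5.5 nM (estimated range 2.5 nM to 12 nM).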

Compound 4, half-maximal inhibitory concentration: 5.7 nM
Beside the measured number, compound 4's estimate is 1.0-fold (0.02 log units) below it; low and high end bracket the measured number.
By their numbers in this assay, from the lowest: compound 2; then compound 1; then compounds 3 and 4 (each within the scatter of the next).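

In this assay, a double bond drawn as Z rather than without a configuration goes with no shift in the read-out (no change at the digits printed from compound 3 to compound 4 (within the scatter)). No group enters or leaves, so the comparison rests on a single difference in the drawing: (the fact that one of compounds 3 and 4 is drawn with a defined configuration and the other without, at the place where they differ). With the double bond drawn as Z in both compounds, the cost of the nitro group also stands without that uncertainty, since putting this group where hydrogen stood gives a large step (a 32-fold higher number from compound 2 to compound 4 (1.50 log units; beyond the scatter)).

Going by these compounds alone, no compound here has the double bond drawn as E, so the drawn Z form has not been compared with its counterpart, and the undefined drawing of compound 3 does not show which form or forms were present. Also open, going by these compounds, is how an amine or a carboxylic acid at the nitro position would compare with the hydrogen of compound 2.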